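Adding benzyloxycarbonyl to compound 3

The source may report more compounds than this note shows. Statements on the series, on what has been measured and on what is new or still open speak of the compounds shown alone.

Compound 1 `c1ccc(-c2nn(-c3ccccc3)cc2-c2nc3ccccc3[nH]2)cc1` gives 3190 nM in a functional assay on MCF7 cells (Homo sapiens) for antiproliferative activity, read by MTT assay, with a stated time of 48 h; a higher number here means a weaker inhibitor, a lower number a stronger inhibitor
Compound 2 `Cc1ccc2[nH]c(-c3cn(-c4ccccc4)nc3-c3ccccc3)nc2c1` gives 5940 nM in this assay
Compound 3 `Fc1ccc(-c2nn(-c3ccccc3)cc2-c2nc3ccccc3[nH]2)cc1` gives 3200 nM in this assay

Compound 3 at 3200 nM stands within the scatter of both other compounds. Compound 4 `O=C(OCc1ccccc1)c1ccc2[nH]c(-c3cn(-c4ccccc4)nc3-c3ccc(F)cc3)nc2c1` is compound 3 with benzyloxycarbonyl in place of hydrogen on an aromatic carbon. Going by the values given here, two measured steps bear on this change. Methyl in place of hydrogen gave a 1.9-fold higher number from compound 1 to compound 2 (0.27 log units; within the scatter) and fluoro in place of hydrogen gave a 1.0-fold higher number from compound 1 to compound 3 (0.00 log units; within the scatter) on the same core. Among the compounds with values here, both groups are much smaller than benzyloxycarbonyl, and no measured compound carries a group of that size. In this assay no step beyond the scatter is therefore expected, only a 1.3-fold higher number from compound 3 to compound 4 (0.10 log units; within the scatter) as an estimate. For compound 4 the estimated value is 4000 nM within an expected range of 1200 nM to 14000 nM and that range is kept wide.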

Compound 4, half-maximal inhibitory concentration: 9240 nM
Compound 4: middle estimate off by 2.3-fold (0.36 log units), on the low side; the range from low to high includes it.
By their numbers in this assay, from the lowest: compounds 1, 3, 2 and 4 (each within the scatter of the next, the first and the last beyond it).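

Placing benzyloxycarbonyl on this aromatic carbon gives a 2.9-fold higher number from compound 3 to compound 4 (0.46 log units; beyond the scatter) in this assay, the first step among these compounds to lie beyond the scatter. The position therefore tolerates a group of this size with only a modest weakening, rather than a complete loss of activity. Nothing available explains this weakening. From the compounds shown here alone, it remains open whether the whole group matters or only part of it. A carboxylic acid, an amine or a benzyl ether on the same carbon could help separate the contributions of its parts.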